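Swapping a phenyl for a larger bicyclic ring on compound 3

The source may report more compounds than this note shows. Statements on the series, on what has been measured and on what is new or still open speak of the compounds shown alone.

Of the compounds shown here, three sharing the same core have been measured in a physicochemical assay for lipophilicity, using the shake flask method; on this read-out higher numbers stand for higher lipophilicity and lower numbers for lower lipophilicity. Compound 3 `O=C(N1CCN(c2ccccc2)CC1)N(c1nccc2ccccc12)[C@@H]1CCCNC1` gives 0.8, the lowest of the three numbers. Its nearest neighbour is compound 1 `Cn1ccc2ccnc(N(C(=O)N3CCC(c4ccccc4)CC3)[C@@H]3CCCNC3)c21`, which in this assay gives 1.4, a gap beyond the usual scatter. Furthest away is compound 2 `O=C(c1ccc(-c2ccccc2)cc1)N(c1nccc2ccccc12)[C@@H]1CCCNC1`, which gives 2.5, again well beyond the scatter.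

Compound 4 `Cc1ccc2c(N3CCN(C(=O)N(c4nccc5ccccc45)[C@@H]4CCCNC4)CC3)noc2c1` has not yet been measured. It differs from compound 3 in one place: a group of 10 heavy atoms (8 carbon, 1 nitrogen, 1 oxygen; one five-membered aromatic ring with 2 hetero atoms, one six-membered aromatic ring of carbon only) in place of a group of 6 heavy atoms (6 carbon; one six-membered aromatic ring of carbon only), on an amine nitrogen in a ring. The entering group carries more heavy atoms than the leaving phenyl and brings two hydrogen-bond acceptors where there were none.

For the measured compounds named here, no measured pair among the three compounds mirrors this exact exchange, so the size of the step cannot be read off directly. The expectation is a moderate upward step from compound 3 to compound 4 of a number 0.80 log units higher from compound 3 to compound 4 (beyond the scatter), beyond the scatter. Compound 4 is therefore estimated at 1.6, with a range from 1 to 2.2.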

Compound 4, distribution coefficient: 1.6
Compound 4: middle estimate and measured number agree at the digits printed; the range from low to high includes it.
By their numbers in this assay, from the lowest: compound 3; then compounds 1 and 4 (each within the scatter of the next); then compound 2.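

In this assay, for the compounds shown here, exchanging the phenyl on the amine nitrogen in a ring gives a number 0.80 log units higher from compound 3 to compound 4 (beyond the scatter), the first step that can be read at this position, so the number here does respond to what this nitrogen carries. The entering group adds a five-membered aromatic ring with 2 hetero atoms and brings 2 hydrogen-bond acceptors to a place that had none, and the number still goes up. Nothing measured here tells what lies behind this step.

With only one step at this position, the compounds shown cannot separate the effect of the added ring atoms from that of the hetero atoms among them. On these data alone, how the number would move with a group carrying an amine or a carboxylic acid in the same place remains open.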